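The compounds below may be only part of what the source reports. "The series", "measured", "known", "first", "only" and "open" are said of these compounds alone.

Compound 1 `CCNC(=O)N1CCC(Oc2cc3nccc(Oc4ccc(NC(=O)NN5C(=O)CSC5c5ccc(F)cc5)cc4)c3cc2OC)CC1` gives 2250 nM in a functional assay on HT-29 cells (Homo sapiens) for inhibition, read by MTT assay; on this read-out lower numbers stand for stronger inhibition and higher numbers for weaker inhibition. Compound 2 `COc1cc2c(Oc3ccc(NC(=O)NN4C(=O)CSC4c4ccc(F)cc4)cc3)ccnc2cc1OC1CCN(C(=O)NC(C)C)CC1` gives 860 nM in this assay.

Compound 2 holds the lowest of the two numbers; its nearest neighbour is compound 1, from which it is separated by the step of a 2.6-fold lower number from compound 1 to compound 2 (0.42 log units; beyond the scatter). Compound 3 `CCCCNC(=O)N1CCC(Oc2cc3nccc(Oc4ccc(NC(=O)NN5C(=O)CSC5c5ccc(F)cc5)cc4)c3cc2OC)CC1` has not yet been measured; it differs from compound 2 by butyl in place of isopropyl on an amide-type nitrogen. Among the measured compounds shown here, only one measured step bears on the group on the amide-type nitrogen, namely a 2.6-fold lower number from compound 1 to compound 2 (0.42 log units; beyond the scatter), a modest move towards stronger inhibition when carbon was added there. Since that step a 2.6-fold lower number from compound 1 to compound 2 (0.42 log units; beyond the scatter) was modest and compound 3 keeps an alkyl group on the same nitrogen, no step beyond the scatter is expected from compound 2 to compound 3: a 1.0-fold higher number from compound 2 to compound 3 (0.02 log units; within the scatter). Compound 3 is therefore expected to give about 900 nM in this assay, with a range from 400 nM to 2000 nM.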

Compound 3, half-maximal inhibitory concentration: 1700 nM
Beside the measured number, compound 3's estimate is 1.9-fold (0.28 log units) below it; low and high end bracket the measured number.
By their numbers in this assay, from the lowest: compounds 2, 3 and 1 (each within the scatter of the next, the first and the last beyond it).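

In this assay, the butyl group on the amide-type nitrogen does not separate compound 3 from either neighbour: the change from isopropyl gives a 2.0-fold higher number from compound 2 to compound 3 (0.30 log units; within the scatter), and the comparison with the ethyl compound gives a 1.3-fold lower number from compound 1 to compound 3 (0.12 log units; within the scatter). The earlier step, a 2.6-fold lower number from compound 1 to compound 2 (0.42 log units; beyond the scatter), therefore does not extend into a simple trend with added carbon, since compound 3 carries the most carbon on this nitrogen yet lies within the scatter of both compound 1 and compound 2. Nothing available here explains these numbers.

The compounds shown leave open whether a longer chain such as hexyl, or a cyclohexyl ring, would stay within the same narrow range. They also leave open how a chain ending in an amine or a carboxylic acid would behave at this nitrogen.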